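Aryl swap on the ring nitrogen: notes on compound 3

A few compounds are considered here, and "the series" means these few. Any claim that something is new, unique, unknown or untested is made for them only; others in the source may bear on it.

compound 1 `Cn1ccc2c(Oc3ccc(NC(=O)c4cn(-c5ccc(Cl)cc5)c5ccccc5c4=O)cc3F)ccnc21`: 290 nM
compound 2 `Cn1ccc2c(Oc3ccc(NC(=O)c4cn(-c5ccc(F)c(Cl)c5)c5ccccc5c4=O)cc3F)ccnc21`: "not determined" (no result reported)

In a functional assay on HepG2 cells (Homo sapiens) for inhibition, read by MTT assay, with a stated time of 72 h (a higher number here means a weaker inhibitor, a lower number a stronger inhibitor), compound 1 gives 290 nM. Compound 2 has "not determined" (no result reported) in this assay, so it stands nowhere on the numbers and offers no anchor of its own. Compound 3 `COc1ccc(-n2cc(C(=O)Nc3ccc(Oc4ccnc5c4ccn5C)c(F)c3)c(=O)c3ccccc32)cc1` carries 4-methoxyphenyl in place of 3-chloro-4-fluorophenyl on an aromatic nitrogen. For the measured compounds named here, no measured pair covers this change, so its size and direction cannot be read from the data; a shift beyond the scatter in either direction is possible, and the only reference point is compound 1 on the shared core. Compound 3 is expected to give 450 nM in this assay, with a range from 120 nM to 2500 nM.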

Compound 3, half-maximal inhibitory concentration: 3750 nM
Estimate against measurement, compound 3: 8.3-fold (0.92 log units) below; measured number above the stated range.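

Methoxy in place of chloro on an aromatic carbon of the aryl group on the ring nitrogen gives a 13-fold higher number from compound 1 to compound 3 (1.11 log units; beyond the scatter) in this assay. For the compounds shown here, this is the first measured step, and it shows that this position is not indifferent to the substituent: the change leads to a weaker inhibitor. Nothing measured here bears on the cause of this shift.

Compound 2 has no number, so steps involving the 3-chloro-4-fluorophenyl group cannot be read. On these data alone, whether an amine, a hydroxyl or a longer alkoxy chain on that carbon would stay close to compound 1 or fall nearer compound 3 remains open.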